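Replacing the pyrazole of compound 2 with 4-fluorophenyl

The source may report more compounds than this note shows. Statements on the series, on what has been measured and on what is new or still open speak of the compounds shown alone.

Compound 1 `O=C1OCCN1c1cc(C(F)(F)F)ccc1[C@H]1CCOc2cc(S(=O)(=O)Nc3nccs3)ccc21`: 295000 nM
Compound 2 `Cn1nccc1-c1cc(C(F)(F)F)ccc1[C@H]1CCOc2cc(S(=O)(=O)Nc3nccs3)ccc21`: 83000 nM

For the measured compounds named here, in a physicochemical assay for solubility (on this read-out higher numbers stand for higher solubility and lower numbers for lower solubility), compound 2 holds the lower of the two numbers so far, at 83000 nM. Compound 3 `O=S(=O)(Nc1nccs1)c1ccc2c(c1)OCC[C@@H]2c1ccc(C(F)(F)F)cc1-c1ccc(F)cc1` keeps the shared core but carries 4-fluorophenyl in place of 1-methyl-1H-pyrazol-5-yl on an aromatic carbon, ortho to a large group and meta to a trifluoromethyl group (4-fluorophenyl in place of 1-methyl-1H-pyrazol-5-yl on an aromatic carbon). Going by the values given here, one measured step bears on this carbon: a 3.6-fold lower number from compound 1 to compound 2 (0.55 log units; beyond the scatter), a modest change that lies beyond the scatter. It involved no ring of carbon only, so it is a loose guide. A step of similar or somewhat larger size, towards a lower number, is expected here. The estimated change is a 3.3-fold lower number from compound 2 to compound 3 (0.52 log units; beyond the scatter). For compound 3 the expected value is 25000 nM, with an estimated range of 6000 nM to 70000 nM.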

Compound 3, solubility: 39000 nM
For compound 3 the middle estimate is 1.6-fold (0.19 log units) below the measured one; low and high end bracket the measured number.
By their numbers in this assay, from the lowest: compound 3; then compound 2; then compound 1.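

At the aromatic carbon ortho to a large group and meta to a trifluoromethyl group, a six-membered aromatic ring of carbon only now joins the comparison, and in this assay 4-fluorophenyl in place of 1-methyl-1H-pyrazol-5-yl gives a 2.1-fold lower number from compound 2 to compound 3 (0.33 log units; beyond the scatter) on this read-out. Against 2-oxo-1,3-oxazolidin-3-yl, the same ring gives a 7.6-fold lower number from compound 1 to compound 3 (0.88 log units; beyond the scatter) in total, so the three groups at this carbon fall in a clear order, with every step beyond the usual scatter. Nothing available here accounts for that order, which stands only as an observation.

The compounds shown leave open where a group without a ring, such as an amine or a carboxylic acid, would fall in this order. They also leave open whether the order holds when the thiazole on the sulfonamide nitrogen is changed.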